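An Unmeasured Ring Exchange on the Shared Core

The compounds below may be only part of what the source reports. "The series", "measured", "known", "first", "only" and "open" are said of these compounds alone.

Results so far in a physicochemical assay for lipophilicity, at pH 7.4 (a higher number here means a more lipophilic compound, a lower number a more polar compound), are:
- Compound 1 `CNc1ccnc2c(O)c(-c3nc(C)n[nH]3)ncc12` gives -0.2 as its value
- Compound 2 `Cc1n[nH]c(-c2ncc3c(N4CCCC4=O)ccnc3c2O)n1` gives "not determined" (no result reported) as its entry

Compound 2 therefore has no single number in this assay and no position on the scale, so the only figure available belongs to compound 1 (-0.2). Compound 3 `Cc1n[nH]c(-c2ncc3c(N4CCCCS4(=O)=O)ccnc3c2O)n1` has not yet been measured. It departs from compound 2 at one place, and the change is a group of 8 heavy atoms (4 carbon, 1 nitrogen, 2 oxygen, 1 sulfur; one six-membered non-aromatic ring with 2 hetero atoms) in place of a group of 6 heavy atoms (4 carbon, 1 nitrogen, 1 oxygen; one five-membered non-aromatic ring with 1 hetero atom), on an aromatic carbon with the 2-oxopyrrolidin-1-yl group leaving. The site lies on an aromatic carbon of a six-membered aromatic ring with 1 nitrogen, opposite the ring nitrogen.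

Within the data shown here, without a number for compound 2, this change has no starting value, and no measured pair shows the size of a comparable step. The step expected in this assay is therefore none beyond the scatter in either direction, with compound 1 (-0.2) as the sole reference. The range is kept wide for that reason. Compound 3 is expected at 0 with an estimated range from -0.6 to 0.6 for its measurement.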

Compound 3, distribution coefficient: 1.5
Compound 3: middle estimate off by 1.50 log units, on the low side, and the stated range ends below it.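

At the aromatic carbon opposite the ring nitrogen, this assay now gives a first measured step: a number 1.70 log units higher from compound 1 to compound 3 (beyond the scatter) when a six-membered non-aromatic ring with 2 hetero atoms replaces the group that compound 1 carries there on the shared core, which shows that the read-out can move well beyond the scatter with the group at this position. The direct exchange of the 2-oxopyrrolidin-1-yl group for that six-membered ring remains unquantified, as compound 2 has no number and the step from it to compound 3 cannot be read. Nothing measured here accounts for the size of the step seen at this position.

The compounds shown leave open how much of the step belongs to the ring and how much to the sulfur with its two oxygens, a question that an open-chain sulfonamide or a piperidine ring on the same aromatic carbon would address. They also leave open where the 2-oxopyrrolidin-1-yl group itself would stand on this scale, and whether a morpholine ring there would track with compound 3.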